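Cytotoxicity notes on a tricyclic series: ester to alcohol

A few compounds are considered here, and "the series" means these few. Any claim that something is new, unique, unknown or untested is made for them only; others in the source may bear on it.

Measured compounds:
- compound 1 `OC12CCCC3CC(CCC31)C2` gives 6000000 nM in an ADME assay (Gallus gallus) for cytotoxicity, read by microscopy, with a stated time of 24 h; on this read-out lower numbers stand for higher toxicity in this test and higher numbers for lower toxicity in this test
- compound 2 `COC(=O)C12CCCC3CC(CCC31)C2` gives 80000 nM in this assay

Going by the values given here, compound 2 stands at the lowest of the two numbers in this assay; its nearest neighbour is compound 1, and the step of a 75-fold lower number from compound 1 to compound 2 (1.88 log units; beyond the scatter) is the only measured step in the set. Compound 3 `OCC12CCCC3CC(CCC31)C2` is not yet measured. It differs from compound 2 as follows: hydroxymethyl in place of methoxycarbonyl on a saturated ring carbon. Among the compounds with values here, the one step that bears on this change is a 75-fold lower number from compound 1 to compound 2 (1.88 log units; beyond the scatter), which separates hydroxy from methoxycarbonyl on the same ring carbon. Hydroxymethyl carries a hydrogen-bond donor as hydroxy does, so the number for compound 3 is expected to move back toward that of compound 1, though not all the way. For compound 3 the expected step is a 13-fold higher number from compound 2 to compound 3 (1.10 log units; beyond the scatter) in this assay. Compound 3 is therefore estimated at 1000000 nM, within a range from 200000 nM to 5000000 nM.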

Compound 3, minimum cytotoxic concentration: 870000 nM
Compound 3: middle estimate off by 1.1-fold (0.06 log units), on the high side; measured number inside the range.
By their numbers in this assay, from the lowest: compound 2; then compound 3; then compound 1.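

In this assay replacing methoxycarbonyl with hydroxymethyl gives an 11-fold higher number from compound 2 to compound 3 (1.04 log units; beyond the scatter) and so shows that the low number of compound 2 does not carry over to a second group with a hydrogen-bond donor on this saturated ring carbon. Both donor-bearing groups stand above methoxycarbonyl across these three compounds, yet they do not match each other: hydroxymethyl in place of hydroxy gives a 6.9-fold lower number from compound 1 to compound 3 (0.84 log units; beyond the scatter) and so the presence of a donor does not alone set the number. No measured property of these groups is available to explain either step.

From the compounds shown here alone, it remains open whether an amine, a carboxylic acid or a longer hydroxyalkyl chain on this ring carbon would fit the same order. Going by these compounds, it also remains open whether the order would hold at another ring carbon of the shared core.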